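A few compounds are considered here, and "the series" means these few. Any claim that something is new, unique, unknown or untested is made for them only; others in the source may bear on it.

Compound 2 `CCCc1c(OCCCCOc2ccc(-c3nn[nH]n3)cc2)ccc(C(=O)CC(C)C)c1O` is the compound with the lowest of the two numbers measured in an assay on isolated protein for binding affinity to metabotropic glutamate receptor 2 (Homo sapiens), read by GTPgammaS binding; on this read-out lower numbers stand for an effect already at smaller amounts and higher numbers for an effect only at larger amounts of compound: compound 2 gives 421 nM. Compound 1 `CC(=O)c1ccc(OCCCCOc2ccc(-c3nn[nH]n3)cc2)c(Br)c1O`, which carries a bromo and an acetyl group on the shared core, gives 878 nM in this assay, a step beyond the usual scatter. Compound 3 `CC(C)CC(=O)c1ccc(OCCCCOc2ccc(-c3nn[nH]n3)cc2)c(Br)c1O` has not yet been measured. It differs from compound 2 by bromo in place of propyl on an aromatic carbon. Compound 1 also carries bromo, so a small step toward a higher number is expected, likely within the scatter: compound 3 is estimated at 600 nM, with a range of 250 nM to 1500 nM, a step of a 1.4-fold higher number from compound 2 to compound 3 (0.15 log units; within the scatter).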

Compound 3, half-maximal effective concentration: 93 nM
Compound 3: middle estimate off by 6.5-fold (0.81 log units), on the high side; measured number outside the range, below it.
By their numbers in this assay, from the lowest: compound 3; then compound 2; then compound 1.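

In this assay, bromo in place of propyl on this aromatic carbon, ortho to a hydroxy group, gives a 4.5-fold lower number from compound 2 to compound 3 (0.66 log units; beyond the scatter) and so goes with a lower number when the isobutylcarbonyl group is present. With bromo kept, isopropyl in place of hydrogen on the saturated chain carbon bound to the carbonyl carbon gives a 9.4-fold lower number from compound 1 to compound 3 (0.98 log units; beyond the scatter) and shows that bromo alone does not set a high number. Open, going by these compounds, is how chloro or an amine at the bromo position, or a longer chain on the carbonyl, would read. No measurement here explains either step.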